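A few compounds are considered here, and "the series" means these few. Any claim that something is new, unique, unknown or untested is made for them only; others in the source may bear on it.

Measured compounds:
compound 1, `COc1ccccc1N1C(=O)CSC1c1cccc(C(=O)NCCCCc2ccc(Cl)cc2)c1`, 78.6 nM
compound 2, `O=C(NCCCCc1ccccc1)c1cccc(C2SCC(=O)N2c2ccc(-c3ccccc3)cc2)c1`, > 1000 nM

In a functional assay on HOS-TE85 cells (Homo sapiens) for inhibition, read by CCK-8 assay, with a stated time of 72 h (a lower number here means a stronger inhibitor, a higher number a weaker inhibitor), compound 2 gives only a limit, > 1000 nM, so its true number is not known. Compound 2 thus sits at the limit of > 1000 nM in this assay, at which 1 of the 2 values shown sits. Compound 1 gives 78.6 nM, but compound 1 and compound 2 differ in several places, so only their two values can be set side by side.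

Compound 3 `CCN(CC)c1ccc(N2C(=O)CSC2c2cccc(C(=O)NCCCCc3ccccc3)c2)cc1` is not yet measured. It differs from compound 2 by diethylamino in place of phenyl on an aromatic carbon. Within the data shown here, no measured step covers this change, so its size in this assay is open; a modest gain is expected, though a step no larger than the scatter cannot be excluded. The expected step is an at least 1.2-fold lower number from compound 2 to compound 3 (0.09 log units; that floor lies within the scatter). Compound 3 is estimated at 800 nM, with a range from 150 nM to 3000 nM.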

Compound 3, half-maximal inhibitory concentration: > 1000 nM
Compound 3: no number, only a limit (the forecaster's own chance of this, stated with the estimate: 45%); at least 1.2-fold (0.09 log units) between middle value and limit.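

Compound 2 and compound 3 both give only a limit, not a number, so no step can be read between them: the limit of > 1000 nM in this assay, at which 2 of the 3 values shown sit.

On these data alone, whether phenyl or diethylamino gives the lower number in this assay stays open.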